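Nitro for Hydrogen on the Benzyl Ring

This account rests on a few compounds, and the source may have more. Where it says the series, first, only, none or still open, it means among the compounds named here.

Compound 1 `Clc1ccc(COc2ccc(OCCOCCNC3CCCC3)cc2)cc1`: 7670 nM
Compound 2 `c1ccc(COc2ccc(OCCOCCNC3CCCC3)cc2)cc1`: 24800 nM

Within the data shown here, compound 2 has the highest number of the two in a functional assay on SK-OV-3 cells (Homo sapiens) for inhibition, read by CCK-8 assay, with a stated time of 70 h (a lower number here means a stronger inhibitor, a higher number a weaker inhibitor), with compound 1 as the only comparison. The change to compound 3 `O=[N+]([O-])c1cccc(COc2ccc(OCCOCCNC3CCCC3)cc2)c1` is nitro in place of hydrogen on an aromatic carbon. Among the measured compounds shown here, one measured step bears on it: a 3.2-fold higher number from compound 1 to compound 2 (0.51 log units; beyond the scatter), showing that a bare ring gives a higher number than a substituted one. A substituent entering again is therefore expected to lower the number modestly, within a 2.1-fold lower number from compound 2 to compound 3 (0.32 log units; beyond the scatter). Compound 3 is estimated at 12000 nM, with a range of 5000 nM to 30000 nM.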

Compound 3, half-maximal inhibitory concentration: 15400 nM
Beside the measured number, compound 3's estimate is 1.3-fold (0.11 log units) below it; low and high end bracket the measured number.
By their numbers in this assay, from the lowest: compounds 1, 3 and 2 (each within the scatter of the next, the first and the last beyond it).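

In this assay the nitro group does not set compound 3 clearly apart from the bare ring, with a 1.6-fold lower number from compound 2 to compound 3 (0.21 log units; within the scatter), and it does not set it clearly apart from the chlorinated ring either, with a 2.0-fold higher number from compound 1 to compound 3 (0.30 log units; within the scatter), although that second step changes the group and its place together. So 3-nitrophenyl does not clearly reproduce the gap seen with 4-chlorophenyl. Nothing available here explains this result.

The compounds shown leave open how chloro and nitro compare at one and the same ring position. They also leave open whether a methoxy group or an amine there would move the number beyond the scatter from compound 2.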